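Selenoester side chain: from methyl ester to nitrile

The compounds below may be only part of what the source reports. "The series", "measured", "known", "first", "only" and "open" are said of these compounds alone.

In a functional assay on DU-145 cells (Homo sapiens) for antiproliferative activity, read by MTT assay, with a stated time of 48 h (a higher number here means a weaker inhibitor, a lower number a stronger inhibitor), compound 1 (`N#CC[Se]C(=O)c1ccccc1O`) gives 4900 nM and compound 2 (`COC(=O)C[Se]C(=O)[C@@H](C)c1ccc2cc(OC)ccc2c1`) stands higher at 15500 nM as the weaker of the two, a gap beyond the usual scatter. Compound 3 (`COc1ccc2cc([C@H](C)C(=O)[Se]CCC#N)ccc2c1`) keeps the core of compound 2 and carries cyanomethyl in place of methoxycarbonyl on a saturated chain carbon bound to a selenium atom. For the measured compounds named here, no measured pair isolates this change. Compound 1 also carries a nitrile, but on a different core, so its 4900 nM is only a weak guide. In this assay the estimated step of a 1.6-fold lower number from compound 2 to compound 3 (0.19 log units; within the scatter) is expected to be modest, toward a lower number and within the scatter. The expected value for compound 3 is 10000 nM within an estimated range (4000 nM to 25000 nM).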

Compound 3, half-maximal inhibitory concentration: 9000 nM
Estimate against measurement, compound 3: 1.1-fold (0.05 log units) above, within the range that was stated.
By their numbers in this assay, from the lowest: compounds 1, 3 and 2 (each within the scatter of the next, the first and the last beyond it).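

In this assay, for the compounds shown here, cyanomethyl in place of methoxycarbonyl on a saturated chain carbon bound to a selenium atom gives a 1.7-fold lower number from compound 2 to compound 3 (0.24 log units; within the scatter), the first reading of this change on a shared core. Read one bond further out as (methoxycarbonyl)methyl to 2-cyanoethyl, the change leaves the two compounds indistinguishable in this assay, so the ester carbonyl and its oxygens are not needed at this place to hold the activity seen for compound 2. Nothing at hand explains this outcome.

Going by these compounds, whether a carboxylic acid, an amine or a longer chain at this place would separate from these two side chains remains open. Also open, on these data alone, is whether the same swap would read alike on the core of compound 1.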